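The compounds below may be only part of what the source reports. "The series", "measured", "known", "first", "only" and "open" are said of these compounds alone.

In an ADME assay on HEp-2 cells (Homo sapiens) for cytotoxicity (on this read-out lower numbers stand for higher toxicity in this test and higher numbers for lower toxicity in this test), compound 2, with structure `CC(C)CCn1c(Cn2c(=O)n(C(C)C)c3ccccc32)nc2ccc(CO)cc21`, gives 81600 nM, the highest of the two numbers measured here. Within the data shown here, compound 1, with structure `CC(C)CCn1c(Cn2c(=O)n(C(C)C)c3ccccc32)nc2ccc(CN)cc21`, gives 28100 nM in this assay, and the one step measured, a 2.9-fold higher number from compound 1 to compound 2 (0.46 log units; beyond the scatter), bears directly on what follows. Compound 3, with structure `CNCc1ccc2nc(Cn3c(=O)n(C(C)C)c4ccccc43)n(CCC(C)C)c2c1`, differs from compound 2 by methylamino in place of hydroxy on a saturated chain carbon bound to an aromatic carbon. Since exchanging the amine for hydroxy raised the number modestly, returning to an amine is expected to lower it again in this assay, roughly back toward compound 1, so compound 3 is estimated at 30000 nM (range 12000 nM to 75000 nM), a step of a 2.7-fold lower number from compound 2 to compound 3 (0.43 log units; beyond the scatter).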

Compound 3, half-maximal cytotoxic concentration: 4810 nM
The estimate for compound 3 lay 6.2-fold (0.79 log units) above the measured number; the measured number lies below the stated range.
By their numbers in this assay, from the lowest: compound 3; then compound 1; then compound 2.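

In this assay, this chain carbon proves more sensitive to the group it carries than the earlier pair suggested, with methylamino in place of hydroxy giving a 17-fold lower number from compound 2 to compound 3 (1.23 log units; beyond the scatter) in this one exchange. The amine itself is not a fixed point either: methyl in place of hydrogen on its nitrogen gives a 5.8-fold lower number from compound 1 to compound 3 (0.77 log units; beyond the scatter) on the same core. No measurement here accounts for either step.

On these data alone, whether a dimethylamino group or an ethylamino group at this place would lower the number further remains open. So does whether a methoxy group would stay close to hydroxy.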